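Vinyl Gives Way to 2-(4-Aminophenyl)ethenyl

A few compounds are considered here, and "the series" means these few. Any claim that something is new, unique, unknown or untested is made for them only; others in the source may bear on it.

In a functional assay on B16 cells (Mus musculus) for inhibition (on this read-out higher numbers stand for weaker inhibition and lower numbers for stronger inhibition), compound 1 `C=CC(=O)OCc1cc(=O)oc2cc(OC)c(OC)cc12` reaches only the limit of the assay, > 10 ug/mL, and so has a limit rather than a number. Compound 3 `COc1cc2oc(=O)cc(COC(=O)/C=C/c3ccc(N)cc3)c2cc1OC` carries 2-(4-aminophenyl)ethenyl in place of vinyl on a carbonyl carbon. Among the measured compounds shown here, no measured step covers this change, so the expectation rests on compound 2 `COc1ccc(/C=C/C(=O)OCc2cc(=O)oc3cc(OC)c(OC)cc23)cc1O`, which gives 3 ug/mL in this assay. A moderate move towards stronger inhibition is expected, and the expected step is an at least 2.0-fold lower number from compound 1 to compound 3 (0.30 log units; that floor lies within the scatter). For compound 3 the estimated value is 5 ug/mL, with an expected range from 1.5 ug/mL to 15 ug/mL.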

Compound 3, half-maximal inhibitory concentration: > 10 ug/mL
Compound 3: no number, only a limit; the forecaster's own chance of this, stated with the estimate: 30%; middle value at least 2.0-fold (0.30 log units) from the limit.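

Replacing 3-hydroxy-4-methoxyphenyl with 4-aminophenyl on the double-bonded chain gives an at least 3.3-fold higher number from compound 2 to compound 3 (0.52 log units; beyond the scatter) in this assay. At this position, then, a six-membered aromatic ring on the ethenyl chain does not by itself keep the number of compound 2; the groups on that ring matter. The step from compound 1 cannot be read, because compound 1 and compound 3 both rest on a limit: the limit of > 10 ug/mL in this assay, at which 2 of the 3 values shown sit.

On these data alone, it remains open whether the hydroxy or the methoxy group matters more in compound 2. Plain phenyl, 4-methoxyphenyl or 3-hydroxyphenyl on the same chain would address this.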